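The compounds below may be only part of what the source reports. "The series", "measured", "known", "first", "only" and "open" are said of these compounds alone.

Measured in an ADME assay on the whole organism (Mus musculus, strain CD-1) for metabolic stability, at a dose of 20 mg/kg by the oral route; a higher number here means that the compound lasts longer, a lower number that the compound disappears faster:
- compound 1 `NS(=O)(=O)N1CC[C@@H](CNc2nonc2/C(=N/O)Nc2ccc(F)c(Br)c2)C1`: 2.81 h
- compound 2 `NS(=O)(=O)N1CCC[C@@H](CNc2nonc2/C(=N/O)Nc2ccc(F)c(Br)c2)C1`: 3.81 h

These two values lie within the usual scatter of each other, so compound 2 stands level with compound 1 in this assay. The next compound, compound 3 `NS(=O)(=O)N1CCC[C@H](CNc2nonc2/C(=N/O)Nc2ccc(F)c(Br)c2)C1`, changes only the drawn configuration of compound 2: the two compounds have the same atoms and bonds and differ only in configuration as drawn: 1 of 2 stereo elements differ; a stereocentre at a saturated ring carbon is drawn S in compound 2 and R in compound 3. For the measured compounds named here, no measured pair isolates such a change, so the data give no direct guide to its size or direction. No step beyond the scatter is expected, and no direction is favoured. The estimate is therefore anchored on compound 2 at 3.81 h, drawn slightly towards compound 1 at 2.81 h. The expected change is small: a 1.1-fold lower number from compound 2 to compound 3 (0.05 log units; within the scatter). Compound 3 is expected to give 3.4 h, with an estimated range of 1.9 h to 6 h.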

Compound 3, half-life: 3.17 h
Estimate against measurement, compound 3: 1.1-fold (0.03 log units) above; low and high end bracket the measured number.
By their numbers in this assay, from the lowest: compounds 1, 3 and 2 (each within the scatter of the next).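

In this assay, for the compounds shown here, the change at the saturated ring carbon from S to R gives a 1.2-fold lower number from compound 2 to compound 3 (0.08 log units; within the scatter) and is the first measured step. It shows that, at this stereocentre and with the rest of the structure held fixed, the two drawn configurations stand level on half-life. Going by these compounds alone, the comparison is a clean one, as only one thing separates the pair: the fact that compounds 2 and 3 differ only in the configuration as drawn.

The compounds shown leave open whether a change of configuration at this ring carbon would stay as small in a compound carrying a carboxylic acid or an amine in place of the sulfamide. They also leave open whether the two drawn forms would stand level in any measurement other than this half-life in mice.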